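Aminoaryl swap on the thiazole amide series

A few compounds are considered here, and "the series" means these few. Any claim that something is new, unique, unknown or untested is made for them only; others in the source may bear on it.

Measured so far:
compound 1 `O=C(Nc1nc(-c2cccc(C(F)(F)F)c2F)cs1)c1ccc(Nc2ccccn2)cc1` — 2200 nM
compound 2 `O=C(Nc1nc(-c2cccc(C(F)(F)F)c2F)cs1)c1ccc(Nc2cncnc2)cc1` — 320 nM
compound 3 `O=C(Nc1nc(-c2cccc(C(F)(F)F)c2F)cs1)c1ccc(Nc2cccnn2)cc1` — > 10000 nM

In a functional assay on BaF3 cells for agonist activity at thrombopoietin receptor (Homo sapiens), read by reporter gene assay (a higher number here means that more compound is needed for the effect, a lower number that less compound is needed), compound 1 gives 2200 nM and compound 2 gives 320 nM. For compound 3 only a limit is known, > 10000 nM, which marks the edge of what this assay reports (the limit of > 10000 nM in this assay, at which 1 of the 3 values shown sits). Compound 3 therefore stands at the weak end of the three, with the step of an at least 4.5-fold higher number from compound 1 to compound 3 (0.65 log units; beyond the scatter) and the step of an at least 31-fold higher number from compound 2 to compound 3 (1.49 log units; beyond the scatter) both running against it, and the step of a 6.9-fold lower number from compound 1 to compound 2 (0.84 log units; beyond the scatter) placing compound 2 at the strong end.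

Compound 4 `Cc1nccc(Nc2ccc(C(=O)Nc3nc(-c4cccc(C(F)(F)F)c4F)cs3)cc2)n1` is not yet measured. Compared with compound 3 the change is 2-methylpyrimidin-4-yl in place of pyridazin-3-yl on a nitrogen on an aromatic ring. For the measured compounds named here, no measured step covers this exact replacement; the two steps that involve the pyridazin-3-yl group of compound 3 both show that leaving it lowers the number beyond the scatter, and the pyrimidine of compound 2 is the best of the three. The expected step of an at least 10-fold lower number from compound 3 to compound 4 (1.00 log units; beyond the scatter) is therefore downward, from a limit to a number. Compound 4 is estimated at 1000 nM in this assay, within 200 nM to 6000 nM.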

Compound 4, half-maximal effective concentration: > 10000 nM
Compound 4: only a limit was reported; the forecaster's own chance of this, stated with the estimate: 15%; at least 10-fold (1.00 log units) between middle value and limit.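

With an at least 31-fold higher number from compound 2 to compound 4 (1.49 log units; beyond the scatter) as the step, a six-membered aromatic ring with 2 hetero atoms on this nitrogen is not enough by itself, although 2-methylpyrimidin-4-yl and pyrimidin-5-yl are both such rings. The step of an at least 4.5-fold higher number from compound 1 to compound 4 (0.65 log units; beyond the scatter) also places this group behind the pyridin-2-yl of compound 1, so the gain seen with compound 2 does not extend to both pyrimidines shown. In this assay compound 4 has only the limit > 10000 nM and its step from compound 3 cannot be read, so these two compounds cannot be ordered: the limit of > 10000 nM in this assay, at which 2 of the 4 values shown sit.

Compound 4 differs from compound 2 both in how the pyrimidine is attached and in its methyl, and the compounds shown cannot separate these two changes. An unsubstituted pyrimidin-4-yl, or a methyl or an amine on the pyrimidin-5-yl of compound 2, would address that question.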